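This account rests on a few compounds, and the source may have more. Where it says the series, first, only, none or still open, it means among the compounds named here.

Measured in an ADME assay on HEL cells (Homo sapiens) for cytotoxicity, with a stated time of 3 days; a higher number here means that more compound is tolerated, a lower number that less compound is tolerated:
Compound 1 `CCCc1ccc(C#Cc2cc3cn([C@H]4C[C@H](O)[C@@H](CO)O4)c(=O)nc3o2)cc1`: > 120000 nM (a limit)
Compound 2 `Cc1ccc(CCc2cc3cn([C@H]4C[C@H](O)[C@@H](CO)O4)c(=O)nc3o2)cc1`: > 540000 nM (a limit)

Compound 2 gives > 540000 nM, and this is a limit, not a number. Compound 1 gives > 120000 nM, which is also a limit. Neither compound therefore has an exact value, and the two cannot be ranked.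

Compound 3 `O=c1nc2oc(C#Cc3ccccc3)cc2cn1[C@H]1C[C@H](O)[C@@H](CO)O1` has not yet been measured. It differs from compound 2 in one place: 2-phenylethynyl in place of 2-(4-methylphenyl)ethyl on an aromatic carbon. In words, 2-phenylethynyl stands in place of 2-(4-methylphenyl)ethyl on an aromatic carbon.

Among the compounds with values here, no measured step guides this change, so the expectation leans on the limit of compound 1 at > 120000 nM. Another limit is the likeliest result in this assay, and the expected step is a moderate one towards less compound tolerated: an at least 2.7-fold lower number from compound 2 to compound 3 (0.43 log units; beyond the scatter). For compound 3 the estimate is 200000 nM, with an expected range from 50000 nM to 600000 nM.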

Compound 3, half-maximal cytotoxic concentration: > 570000 nM
Compound 3 ended at the assay's limit (the forecaster's own chance of this, stated with the estimate: 75%); middle value at least 2.8-fold (0.45 log units) away from the limit.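

In this assay compound 3 gives > 570000 nM, which is a limit. The steps to compound 3 from compound 1 and from compound 2 cannot be read, as all three values are limits. The compounds shown leave open the concentration at which any of them harms these cells, and how they rank.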